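The source may report more compounds than this note shows. Statements on the series, on what has been measured and on what is new or still open speak of the compounds shown alone.

Working notes on the series. For the measured compounds named here, the shared core of compound 1, `COc1ccc(N(C)c2ccnc(Cl)n2)cc1`, carries a hydrogen on an aromatic carbon of a six-membered aromatic ring of carbon only, ortho to a methoxy group; in a functional assay on HeLa cells (Homo sapiens) for antiproliferative activity, read by MTT assay, with a stated time of 48 h (on this read-out higher numbers stand for weaker inhibition and lower numbers for stronger inhibition), compound 1 gives 917 nM, the second highest of the three numbers measured so far. Compound 2, `COc1ccc(N(C)c2ccnc(Cl)n2)cc1O`, gives 96 nM, and the step of a 9.6-fold lower number from compound 1 to compound 2 (0.98 log units; beyond the scatter) is the only move toward a lower number in the set. Compound 3, `COc1ccc(N(C)c2ccnc(Cl)n2)cc1OCCCCCBr`, gives 7090 nM; the step of a 7.7-fold higher number from compound 1 to compound 3 (0.89 log units; beyond the scatter) and the step of a 74-fold higher number from compound 2 to compound 3 (1.87 log units; beyond the scatter) both show that putting a chain on the oxygen at this position brings a higher number.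

Compound 4, `COc1ccc(N(C)c2ccnc(Cl)n2)cc1OCCC[Se]C#N`, changes compound 1 by a group of 7 heavy atoms (4 carbon, 1 nitrogen, 1 oxygen, 1 selenium; no ring) in place of a hydrogen atom, on an aromatic carbon. Going by the values given here, the change most like it is the one from compound 1 to compound 3, where an alkoxy chain also replaced the hydrogen, so a step toward a higher number is expected for compound 4, of roughly a 4.9-fold higher number from compound 1 to compound 4 (0.69 log units; beyond the scatter). Compound 4 is therefore estimated at 4500 nM, within 1200 nM to 16000 nM.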

Compound 4, half-maximal inhibitory concentration: 4710 nM
Beside the measured number, compound 4's estimate is 1.0-fold (0.02 log units) below it, and the stated range covers the measured number.
By their numbers in this assay, from the lowest: compound 2; then compound 1; then compounds 4 and 3 (each within the scatter of the next).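

In this assay, the end of the chain on the oxygen can be exchanged with no readable consequence: a 1.5-fold lower number from compound 3 to compound 4 (0.18 log units; within the scatter), with a selenium-bearing group in place of the bromine-bearing end. The loss seen on substituting this oxygen is thus not tied to the 5-bromopentyl chain, since a 49-fold higher number from compound 2 to compound 4 (1.69 log units; beyond the scatter) and a 5.1-fold higher number from compound 1 to compound 4 (0.71 log units; beyond the scatter) run the same way with a different chain and chain end. No supporting data bear on what lies behind these steps.

Going by these compounds, it remains open whether a short group on this oxygen, such as ethyl, would stay closer to compound 2 than these chains do. Also open, on these data alone, is whether the selenium itself contributes anything, which a chain ending in a plain nitrile, an amine or a carboxylic acid would test.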